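Swapping the aryl ether arm for an aryl ketone chain

This account rests on a few compounds, and the source may have more. Where it says the series, first, only, none or still open, it means among the compounds named here.

Measured compounds:
compound 1 `CC(C)C[C@H](N)c1cc(C(F)(F)F)ccc1N1CCN(C(=O)C(C)Cc2ccc(Cl)cc2O)CC1` 36 nM
compound 2 `CC(C)C[C@H](N)c1cc(C(F)(F)F)ccc1N1CCN(C(=O)COc2cccc(Cl)c2Cl)CC1` 2500 nM
compound 3 `CC(C)C[C@H](N)c1cc(C(F)(F)F)ccc1N1CCN(C(=O)COc2cccc3ccccc23)CC1` 2600 nM

In an assay on HEK293 cells for displacement of a labelled ligand from Melanocortin receptor 4 (Homo sapiens) (a higher number here means a weaker inhibitor, a lower number a stronger inhibitor), compound 2 sits second highest of the three numbers. Compound 3 lies within the scatter of it, as a 1.0-fold higher number from compound 2 to compound 3 (0.02 log units; within the scatter) shows, while compound 1 is far lower, by a 69-fold higher number from compound 1 to compound 2 (1.84 log units; beyond the scatter). Compound 4 `CC(C)C[C@H](N)c1cc(C(F)(F)F)ccc1N1CCN(C(=O)CCC(=O)c2ccc(Cl)cc2)CC1` arises from compound 2 by the change (((4-chlorophenyl)carbonyl)methyl in place of 2,3-dichlorophenoxy on a saturated chain carbon bound to a carbonyl carbon). Among the measured compounds shown here, no measured step alters the link between the carbonyl and the aromatic ring; a 1.0-fold higher number from compound 2 to compound 3 (0.02 log units; within the scatter) only shows that changing the aryl on the oxygen did nothing, and a 69-fold higher number from compound 1 to compound 2 (1.84 log units; beyond the scatter) that the 1-(4-chloro-2-hydroxybenzyl)ethyl arm is far stronger than the ether. Compound 4 keeps neither, so compound 4 is expected near compound 2, estimated at 1500 nM (range 300 nM to 6000 nM), a step of a 1.7-fold lower number from compound 2 to compound 4 (0.22 log units; within the scatter) expected.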

Compound 4, inhibition constant: 820 nM
Compound 4: middle estimate off by 1.8-fold (0.26 log units), on the high side; the range from low to high includes it.
By their numbers in this assay, from the lowest: compound 1; then compound 4; then compounds 2 and 3 (each within the scatter of the next).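

In this assay, the ((4-chlorophenyl)carbonyl)methyl arm shows that this position responds to more than the aryl on the oxygen, with steps beyond the scatter (a 3.0-fold lower number from compound 2 to compound 4 (0.48 log units; beyond the scatter); a 3.2-fold lower number from compound 3 to compound 4 (0.50 log units; beyond the scatter)). The link and the chlorine pattern change together in these steps, so their contributions cannot be separated. The 1-(4-chloro-2-hydroxybenzyl)ethyl arm keeps a large lead (a 23-fold higher number from compound 1 to compound 4 (1.36 log units; beyond the scatter)), and no evidence available here bears on these differences.

As far as these compounds go, it remains open whether a secondary amide or a sulfonyl in place of the ketone carbonyl of compound 4 would lower the number further.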